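The source may report more compounds than this note shows. Statements on the series, on what has been measured and on what is new or still open speak of the compounds shown alone.

Measured compounds:
compound 1 `COc1ccc(/C=N/Nc2nc3ccccc3nc2Cc2ccccc2)cc1`, 63 nM
compound 2 `Oc1ccc(/C=N/Nc2nc3ccccc3nc2Cc2ccccc2)cc1`, 3.4 nM

For the measured compounds named here, compound 2 gives the lowest number of the two in an assay on isolated protein for inhibition of Amine oxidase [flavin-containing] A (Homo sapiens), read by spectrophotometry; a higher number here means a weaker inhibitor, a lower number a stronger inhibitor; its nearest neighbour is compound 1, which gives 63 nM, and the step of a 19-fold lower number from compound 1 to compound 2 (1.27 log units; beyond the scatter) is the only measured step. That step, a hydrogen in place of a methyl on an oxygen on an aromatic ring, lies within the part of compound 2 that is now removed.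

Compound 3 `C=NNc1nc2ccccc2nc1Cc1ccccc1` is the unmeasured compound. It differs from compound 2 by a group of 2 heavy atoms (1 carbon, 1 nitrogen; no ring) in place of a group of 9 heavy atoms (7 carbon, 1 nitrogen, 1 oxygen; one six-membered aromatic ring of carbon only), on a nitrogen on an aromatic ring. Going by the values given here, the one measured step bears only indirectly on this change: it shows that the oxygen-bearing end of the leaving group carries a large part of the difference between compound 1 and compound 2, and that whole group, hydroxyl and ring together, is gone in compound 3. A large step upward, beyond the scatter, is therefore expected: a 120-fold higher number from compound 2 to compound 3 (2.07 log units; beyond the scatter). For compound 3 the expected value in this assay is 400 nM, within a range of 60 nM to 3000 nM.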

Compound 3, half-maximal inhibitory concentration: 86 nM
The estimate for compound 3 lay 4.7-fold (0.67 log units) above the measured number; low and high end bracket the measured number.
By their numbers in this assay, from the lowest: compound 2; then compounds 1 and 3 (each within the scatter of the next).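

In this assay, the change on the nitrogen on an aromatic ring gives a 25-fold higher number from compound 2 to compound 3 (1.40 log units; beyond the scatter) and so shows that the low number of compound 2 depends on the whole group of 9 heavy atoms, not on the shared core alone. It also puts the earlier step in a new light: compound 3, which has no such group, lies within the scatter of compound 1 at 63 nM in this assay, so the larger group with its oxygen methylated shows no measurable gain over the group of 2 heavy atoms. Nothing available explains why these numbers fall as they do.

The compounds shown leave open whether the aromatic ring is needed at all, or whether a hydroxyl on a short chain would serve as well. They also leave open whether an amine or a carboxylic acid on the ring, in place of the hydroxyl, would keep the number of compound 2.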